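The source may hold more compounds than are shown below. What is called first, only, known or untested is meant among the compounds shown, and "the series" means these compounds.

Going by the values given here, compound 2, `C/C(=C\CC/C(C)=C/CC[C@@H]1[C@@]2(C)CCC(=O)C(C)(C)[C@H]2CC[C@@]1(C)O)CC/C=C(\C)C(=O)OCc1cn(-c2cccc(Cl)c2)nn1`, is the only compound of the pair to return a number in a functional assay on MDA-MB-231 cells (Homo sapiens) for antiproliferative activity, read by MTT assay, with a stated time of 48 h (on this read-out higher numbers stand for weaker inhibition and lower numbers for stronger inhibition), where compound 2 gives 103000 nM. Compound 1, `C/C(=C\CC/C(C)=C/CC[C@@H]1[C@@]2(C)CCC(=O)C(C)(C)[C@H]2CC[C@@]1(C)O)CC/C=C(\C)C(=O)OCc1cn(-c2ccccc2Cl)nn1`, returns a limit rather than a number, > 150000 nM. Among the compounds with values here, the single measured step, an at least 1.4-fold lower number from compound 1 to compound 2 (0.16 log units; that floor lies within the scatter), rests on that limit, (the limit of > 150000 nM in this assay, at which 1 of the 2 values shown sits), and so cannot be sized beyond its floor. Compound 3, `COc1ccc(-n2cc(COC(=O)/C(C)=C/CC/C(C)=C/CC/C(C)=C/CC[C@@H]3[C@@]4(C)CCC(=O)C(C)(C)[C@H]4CC[C@@]3(C)O)nn2)cc1`, differs from compound 2 at the same aromatic nitrogen: 4-methoxyphenyl in place of 3-chlorophenyl on an aromatic nitrogen. Within the data shown here, the only step that bears on this change is the one from compound 1 to compound 2, and its floor lies within the scatter, so the account offers no ground for expecting a shift beyond the scatter in either direction in this assay. Compound 3 is therefore expected to stand close to compound 2, with an estimated step of a 1.0-fold lower number from compound 2 to compound 3 (0.01 log units; within the scatter). The estimate for compound 3 in this assay is 100000 nM, within a range from 40000 nM to 250000 nM.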

Compound 3, half-maximal inhibitory concentration: > 150000 nM
Compound 3 gave a limit, no number; the forecaster's own chance of this, stated with the estimate: 35%; middle value at least 1.5-fold (0.17 log units) away from the limit.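

Compound 3 returns a limit in this assay, not a number, so it joins compound 1 in giving no measured value. The step, an at least 1.4-fold higher number from compound 2 to compound 3 (0.16 log units; that floor lies within the scatter), rests on that limit and cannot be sized beyond its floor, so the change from 3-chlorophenyl to 4-methoxyphenyl on this aromatic nitrogen is not shown to move the read-out beyond the scatter. Of the three groups placed here, only the one in compound 2 gives a number, and the step between compound 1 and compound 3 cannot be read: the limit of > 150000 nM in this assay, at which 2 of the 3 values shown sit.

The compounds shown leave open how far compound 1 and compound 3 lie past that limit. They also leave open what a plain phenyl, or a phenyl carrying an amine or a carboxylic acid, would give on this nitrogen in this assay.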